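Substituents on the piperidine nitrogen chain: a third variant

This account rests on a few compounds, and the source may have more. Where it says the series, first, only, none or still open, it means among the compounds named here.

Compound 2 `COC(=O)N(C)CC(O)CN1CCC(CNC(=O)c2cccc3[nH]c(C(C)C)nc23)CC1` shares its core with compound 1 `CC(C)c1nc2c(C(=O)NCC3CCN(CCN4CCN(S(C)(=O)=O)CC4)CC3)cccc2[nH]1` and differs from it only at a saturated chain carbon bound to an amine nitrogen in a ring. In an assay on isolated protein for binding affinity to 5-hydroxytryptamine receptor 3A (Homo sapiens) (on this read-out lower numbers stand for stronger inhibition and higher numbers for weaker inhibition), compound 2 gives 50100 nM, while compound 1 gives 100000 nM; the two numbers lie within the usual scatter of one another, as a 2.0-fold lower number from compound 1 to compound 2 (0.30 log units; within the scatter) shows, so neither can be called stronger. Compound 3 `CC(=O)N1CCC(CN2CCC(CNC(=O)c3cccc4[nH]c(C(C)C)nc34)CC2)CC1` is the unmeasured variant; relative to compound 2 the change is 1-acetylpiperidin-4-yl in place of 1-hydroxy-2-((methoxycarbonyl)(methyl)amino)ethyl on a saturated chain carbon bound to an amine nitrogen in a ring. Among the compounds with values here, the only measured step that bears on it is a 2.0-fold lower number from compound 1 to compound 2 (0.30 log units; within the scatter), which exchanged a group at the same place without moving the number beyond the scatter. On that basis, the step of a 1.2-fold higher number from compound 2 to compound 3 (0.08 log units; within the scatter) is expected to stay within the scatter as well, with no clear direction. For compound 3 the estimated value in this assay is 60000 nM, with a range from 20000 nM to 200000 nM, and a real possibility that only a limit is reported.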

Compound 3, inhibition constant: 100000 nM
Compound 3: the middle estimate sits 1.7-fold (0.22 log units) below what was measured, within the range that was stated.
By their numbers in this assay, from the lowest: compounds 2, 1 and 3 (each within the scatter of the next).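

In this assay, 1-acetylpiperidin-4-yl in place of 1-hydroxy-2-((methoxycarbonyl)(methyl)amino)ethyl gives a 2.0-fold higher number from compound 2 to compound 3 (0.30 log units; within the scatter), and the same group in place of (4-(methylsulfonyl)piperazin-1-yl)methyl gives no change at the digits printed from compound 1 to compound 3 (within the scatter), so three different groups on this saturated chain carbon bound to an amine nitrogen in a ring now lie within the scatter of one another. The new pair adds a contrast the first did not isolate: the group that leaves compound 2 has no ring and 1 hydrogen-bond donor, the group that enters compound 3 has one six-membered non-aromatic ring and 0 hydrogen-bond donors, and the numbers still cannot be told apart. No supporting measurement accounts for how closely these numbers agree.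

The three compounds leave open whether any group at this place can carry the number beyond the scatter, for instance a carboxylic acid, a primary amine, a phenyl ring or a longer chain. They also leave open whether this position would respond more clearly if the shared core carried a different group in place of its isopropyl.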